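Compound 1 at the top of a two-point series

A few compounds are considered here, and "the series" means these few. Any claim that something is new, unique, unknown or untested is made for them only; others in the source may bear on it.

Measured in a functional assay on DU-145 cells (Homo sapiens) for inhibition, read by trypan blue exclusion, with a stated time of 96 h; a higher number here means a weaker inhibitor of growth, a lower number a stronger inhibitor of growth:
- compound 1 `Cc1ccc(CS/C(=C/c2ccc(F)c(C)c2)C(=O)c2ccc(Cl)cc2)cc1`: 25000 nM
- compound 2 `COc1ccccc1/C=C(/SCc1ccc(Cl)c(Cl)c1)C(=O)c1ccc(Cl)cc1`: 10000 nM

In this assay compound 1, at 25000 nM, has the higher of the two numbers and so is the weaker inhibitor of growth. Compound 2 stands at 10000 nM, and the gap between the two lies beyond the usual scatter.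

Compound 3 `Cc1ccc(CS/C(=C/c2ccc(O)c(O)c2O)C(=O)c2ccc(Cl)cc2)cc1` keeps the rest of compound 1 and carries 2,3,4-trihydroxyphenyl in place of 4-fluoro-3-methylphenyl on a double-bonded chain carbon bound to a double-bonded chain carbon. Among the compounds with values here, no measured pair differs in one place only, so the data give no direct size for such an exchange. Within the data shown here, compound 2, at 10000 nM, shows only that numbers lower than that of compound 1 occur. A step beyond the scatter towards stronger inhibition in this assay is expected, though with wide uncertainty. The estimated change is an 8.3-fold lower number from compound 1 to compound 3 (0.92 log units; beyond the scatter). For compound 3 the expected value is 3000 nM, with an estimated range of 400 nM to 20000 nM.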

Compound 3, concentration for 50% growth inhibition: 50000 nM
Compound 3: the middle estimate sits 17-fold (1.22 log units) below what was measured, and the stated range ends below it.
By their numbers in this assay, from the lowest: compound 2; then compounds 1 and 3 (each within the scatter of the next).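

In this assay, within the data shown here, the exchange of 4-fluoro-3-methylphenyl for 2,3,4-trihydroxyphenyl on a double-bonded chain carbon bound to a double-bonded chain carbon gives the only single-place step, a 2.0-fold higher number from compound 1 to compound 3 (0.30 log units; within the scatter). At this position, then, an aryl group with 3 hydrogen-bond donors and 3 hydrogen-bond acceptors cannot be told apart in growth inhibition from one with 0 of each, so this exchange gives no readable effect here, and the series now holds a first direct size for a change at this place. No supporting measurement bears on why the two groups read alike.

Still open, on these data alone, is whether a phenyl ring carrying an amine or a carboxylic acid at this same position would give a number clearly apart from those of compound 1 and compound 3. Also open, as far as these compounds go, is whether the same exchange of 4-fluoro-3-methylphenyl for 2,3,4-trihydroxyphenyl would give a step of similar size on a shared core with a different group on the sulfur-bound benzyl side.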